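Replacing the pyridine ester on a shared core

The compounds below may be only part of what the source reports. "The series", "measured", "known", "first", "only" and "open" are said of these compounds alone.

compound 1 `O=C(Oc1ccc2ccc(Cl)ccc1-2)c1ccccc1`: 0.1%
compound 2 `O=C(Oc1ccc2ccc(Cl)ccc1-2)c1cccnc1`: -2.4%

Both measured compounds were tested in an assay on cells for displacement of a labelled ligand from Orexin/Hypocretin receptor type 1 (Homo sapiens), read by scintillation counting, with stated times of 10 min and 90 min, tested at 10 uM; a higher number here means more inhibition at the concentration tested (going by the name of the read-out), a lower number less inhibition. Compound 1 gives 0.1% and compound 2 gives -2.4%; these two numbers lie within the scatter of each other, so neither compound shows inhibition that can be told from zero, and compound 2 cannot be said to sit lower or higher than compound 1 in any meaningful sense.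

Compound 3 `COC(=O)CCC(=O)Oc1ccc2ccc(Cl)ccc1-2` has not yet been measured. It differs from compound 2 in one place: 2-(methoxycarbonyl)ethyl in place of pyridin-3-yl on a carbonyl carbon. Among the compounds with values here, the only measured step that bears on this change is a number 2.5 percentage points lower from compound 1 to compound 2 (within the scatter), where one aromatic group on the carbonyl carbon was swapped for another without moving the number beyond the scatter. That step gives no sign that the group on the carbonyl carbon shifts the read-out, although a non-aromatic chain has not been tried, so the expectation rests on thin ground.

Compound 3 is therefore expected to show a step of a number 2.4 percentage points higher from compound 2 to compound 3 (within the scatter), that is, nothing beyond the scatter. The estimate for compound 3 is 0%, with a range from -10% to 12%.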

Compound 3, a percentage reported as inhibition, at one concentration (the size of the read-out at that concentration, not a potency): 8%
The estimate for compound 3 lay 8 percentage points below the measured number; the range from low to high includes it.
By their numbers in this assay, from the lowest: compounds 2, 1 and 3 (each within the scatter of the next, the first and the last beyond it).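

In this assay, the group on the carbonyl carbon now gives its first step beyond the scatter: with 2-(methoxycarbonyl)ethyl, a chain with no ring, in place of pyridin-3-yl, the read-out shows a number 10.4 percentage points higher from compound 2 to compound 3 (beyond the scatter), whereas the exchange of one aromatic ring for another had not moved the number beyond the scatter. The comparison with the phenyl compound is weaker, showing a number 7.9 percentage points higher from compound 1 to compound 3 (within the scatter), so the chain stands clearly apart from only one of the two aromatic groups, and even compound 3 gives only 8% at the single concentration tested. No measurement here offers a reason for the step.

Within the data shown here, these compounds cannot show whether the modest step belongs to the open chain as such or to the ester within it, since only one non-aromatic group appears among them. Going by these compounds, a carboxylic acid, an amine or a longer chain in place of 2-(methoxycarbonyl)ethyl could help separate these possibilities, and it remains open whether any group at this position can give inhibition well above this low level.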